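Hydroxyaryl hydrazone series: naphthyl in place of phenyl

A few compounds are considered here, and "the series" means these few. Any claim that something is new, unique, unknown or untested is made for them only; others in the source may bear on it.

Three hydrazone analogues on the shared core have numbers in a functional assay on NCI-H460 cells (Homo sapiens) for cytotoxicity, read by MTT assay, with a stated time of 72 h; a lower number here means a stronger inhibitor, a higher number a weaker inhibitor. Compound 1 `CN(C)CCn1cnnc1-c1cc(Oc2ccc(NC(=O)N/N=C/c3cccc(Br)c3)cc2F)ccn1` gives 520 nM. Compound 2 `CN(C)CCn1cnnc1-c1cc(Oc2ccc(NC(=O)N/N=C/c3cccc(Cl)c3Cl)cc2F)ccn1` gives 72 nM. Compound 3 `CN(C)CCn1cnnc1-c1cc(Oc2ccc(NC(=O)N/N=C/c3ccc(O)cc3)cc2F)ccn1` gives 1780 nM, the highest number of the three: the step is a 3.4-fold higher number from compound 1 to compound 3 (0.53 log units; beyond the scatter), and a 25-fold higher number from compound 2 to compound 3 (1.39 log units; beyond the scatter). Between the halogenated pair the step is a 7.2-fold lower number from compound 1 to compound 2 (0.86 log units; beyond the scatter).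

Compound 4 `CN(C)CCn1cnnc1-c1cc(Oc2ccc(NC(=O)N/N=C/c3c(O)ccc4ccccc34)cc2F)ccn1` is not yet measured. It differs from compound 3 as follows: 2-hydroxynaphthalen-1-yl in place of 4-hydroxyphenyl on a carbon with a double bond to nitrogen. Among the measured compounds shown here, the only steps that bear on this change are those arriving at the 4-hydroxyphenyl compound, a 3.4-fold higher number from compound 1 to compound 3 (0.53 log units; beyond the scatter) and a 25-fold higher number from compound 2 to compound 3 (1.39 log units; beyond the scatter); both show that this aryl group sits at the weak end of the set. For the measured compounds named here, no measured compound carries a second aromatic ring at this position, so the direction for compound 4 cannot be read from a matched step. Because compound 3 stands at 1780 nM and every other aryl group shown gives a lower number, compound 4 is expected to move downward by a modest step, a 2.2-fold lower number from compound 3 to compound 4 (0.35 log units; beyond the scatter). The estimate for compound 4 in this assay is 800 nM, with a range from 250 nM to 2500 nM.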

Compound 4, half-maximal inhibitory concentration: 890 nM
The estimate for compound 4 lay 1.1-fold (0.05 log units) below the measured number; measured number inside the range.
By their numbers in this assay, from the lowest: compound 2; then compounds 1, 4 and 3 (each within the scatter of the next, the first and the last beyond it).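

In this assay, a second aromatic ring on the carbon with a double bond to nitrogen does not separate the hydroxylated aryl series from its neighbours: compound 4 stays within the scatter of both compound 3 (a 2.0-fold lower number from compound 3 to compound 4 (0.30 log units; within the scatter)) and compound 1 (a 1.7-fold higher number from compound 1 to compound 4 (0.23 log units; within the scatter)). The larger 2-hydroxynaphthalen-1-yl group therefore does not close the gap to the 2,3-dichlorophenyl group, which remains well apart (a 12-fold higher number from compound 2 to compound 4 (1.09 log units; beyond the scatter)). No measurement shown explains these numbers.

Between compound 3 and compound 4, the ring count and the attachment of the hydroxyl change together, so their separate contributions remain open. A plain naphthalen-1-yl group or a 2-methoxynaphthalen-1-yl group on the shared core would address that question.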